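A few compounds are considered here, and "the series" means these few. Any claim that something is new, unique, unknown or untested is made for them only; others in the source may bear on it.

Compounds with numbers so far:

Compound 1 `CN(C)CCn1cnnc1-c1cc(Oc2ccc(NC(=O)N/N=C/c3ccccc3O[N+](=O)[O-])cc2F)ccn1` — in an ADME assay on WI-38 cells (Homo sapiens) for cytotoxicity, read by MTT assay, with a stated time of 72 h (on this read-out lower numbers stand for stronger inhibition and higher numbers for weaker inhibition), compound 1 gives 6860 nM.
Compound 2 `CN(C)CCn1cnnc1-c1cc(Oc2ccc(NC(=O)N/N=C/c3ccc(F)cc3F)cc2F)ccn1` — in this assay compound 2 gives 5030 nM.
Compound 3 `COc1cc(/C=N/NC(=O)Nc2ccc(Oc3ccnc(-c4nncn4CCN(C)C)c3)c(F)c2)cc(OC)c1OC` — in this assay compound 3 gives "not determined" (no result reported); it stands nowhere on the numbers, as the read-out was not determined for it.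

The compound to be placed next is compound 4 `CN(C)CCn1cnnc1-c1cc(Oc2ccc(NC(=O)N/N=C/c3cccc(Cl)c3Cl)cc2F)ccn1`. It differs from compound 3 in one place: 2,3-dichlorophenyl in place of 3,4,5-trimethoxyphenyl on a carbon with a double bond to nitrogen.

Among the measured compounds shown here, only one measured step bears on this kind of change, an exchange of the aryl group on the carbon with a double bond to nitrogen: a 1.4-fold lower number from compound 1 to compound 2 (0.13 log units; within the scatter). That swap, between two differently substituted phenyl groups on the same carbon, left the number essentially where it was. Compound 3 itself contributes no anchor. The expectation for compound 4 in this assay therefore rests on compounds 1 and 2 alone, and no step beyond the scatter is expected from changing the aryl group here.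

Compound 4 is expected to give about 6000 nM in this assay, with a range from 2500 nM to 15000 nM.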

Compound 4, half-maximal inhibitory concentration: 6130 nM
Estimate against measurement, compound 4: 1.0-fold (0.01 log units) below; the measured number falls inside the stated range.
By their numbers in this assay, from the lowest: compounds 2, 4 and 1 (each within the scatter of the next).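

In this assay, a third aryl group on the carbon with a double bond to nitrogen again leaves the number within the scatter (a 1.2-fold higher number from compound 2 to compound 4 (0.09 log units; within the scatter); a 1.1-fold lower number from compound 1 to compound 4 (0.05 log units; within the scatter)). The three groups with numbers, 2-(nitrooxy)phenyl, 2,4-difluorophenyl and 2,3-dichlorophenyl, therefore cannot be told apart in this read-out, now including a pair of chlorine atoms on the ring, although the step from compound 3 cannot be read as compound 3 has no number. No supporting data on any property of these groups accompany this result.

The compounds shown leave open whether an aryl group carrying an amine or a carboxylic acid at this place would stay within the same narrow band. They also leave open whether a saturated ring such as cyclohexyl in place of the aryl group would do so.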